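Removing the Sugar from a Disulfide-Linked Fluorouracil Conjugate

The source may report more compounds than this note shows. Statements on the series, on what has been measured and on what is new or still open speak of the compounds shown alone.

Compound 2 `O=C(CCCSSCCOCCOCCOc1cc(O)c(C(=O)CCc2ccc(O)cc2)c(O[C@@H]2O[C@H](CO)[C@@H](O)[C@H](O)[C@H]2O)c1)OCn1cc(F)c(=O)[nH]c1=O` was tested in a functional assay on HT-29 cells (Homo sapiens) for cytotoxicity, read by sulforhodamine B assay, with a stated time of 48 h (on this read-out higher numbers stand for weaker inhibition and lower numbers for stronger inhibition), where compound 2 gives 59800 nM. Going by the values given here, compound 1 `O=C(CCCCCN1C(=O)CC(SCCOCCOCCOc2cc(O)c(C(=O)CCc3ccc(O)cc3)c(O)c2)C1=O)OCn1cc(F)c(=O)[nH]c1=O` is the only other measured compound; in this assay compound 1 gives 43700 nM, and the two numbers sit within the usual scatter of each other, so neither can be called the stronger. Compound 3 `O=C(CCCSSCCOCCOCCOc1cc(O)c(C(=O)CCc2ccc(O)cc2)c(O)c1)OCn1cc(F)c(=O)[nH]c1=O` differs from compound 2 by hydrogen in place of 3,4,5-trihydroxy-6-(hydroxymethyl)oxan-2-yl on an oxygen on an aromatic ring, leaving a hydroxy group at that position. Among the compounds with values here, no measured pair isolates this change, so the expected step, a 1.3-fold lower number from compound 2 to compound 3 (0.12 log units; within the scatter), is none beyond the scatter. Compound 3 is therefore estimated to give about 45000 nM in this assay, within a range from 18000 nM to 110000 nM.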

Compound 3, half-maximal inhibitory concentration: 19600 nM
Beside the measured number, compound 3's estimate is 2.3-fold (0.36 log units) above it, within the range that was stated.
By their numbers in this assay, from the lowest: compound 3; then compounds 1 and 2 (each within the scatter of the next).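

In this assay, putting hydrogen in place of 3,4,5-trihydroxy-6-(hydroxymethyl)oxan-2-yl gives a 3.1-fold lower number from compound 2 to compound 3 (0.48 log units; beyond the scatter) and is a modest change beyond the scatter. It shows that what sits on this oxygen on an aromatic ring can change the read-out, with the free hydroxy group giving the stronger inhibition of this pair. Nothing available explains why. Only the sugar and hydrogen are compared at this oxygen, so a methyl group or a carboxylic acid on a short chain there remains an open case.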